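The compounds below may be only part of what the source reports. "The series", "measured", "known", "first", "only" and "open" are said of these compounds alone.

Working notes on the series. Compound 1 `COc1cc(N(Cc2ccc(C)cc2)C(=O)CSC(=S)N2CCN(C(=O)OC(C)(C)C)CC2)cc(OC)c1OC` and compound 2 `COc1ccc(CN(C(=O)CSC(=S)N2CCN(C(=O)OC(C)(C)C)CC2)c2cc(OC)c(OC)c(OC)c2)cc1OC` share one core. In a functional assay on KYSE-450 cells (Homo sapiens) for inhibition, read by CCK-8 assay, with a stated time of 48 h (on this read-out higher numbers stand for weaker inhibition and lower numbers for stronger inhibition), compound 1 gives only a limit of the assay, > 20000 nM. In this assay compound 2 likewise gives only a limit, > 20000 nM. The step that the two limits leave unreadable from compound 1 to compound 2 is therefore unreadable, both ends sitting at the limit (the limit of > 20000 nM in this assay, at which 2 of the 2 values shown sit). Compound 2 thus stands nowhere more precisely than at that limit, alongside compound 1. Compound 3 `COc1ccc(CN(C(=O)CSC(=S)N2CCN(C(=O)OC(C)(C)C)CC2)c2cc(OC)c(OC)c(OC)c2)cc1F` differs from compound 2 by fluoro in place of methoxy on an aromatic carbon. For the measured compounds named here, no measured step bears on this change; the only measured step, a step that the two limits leave unreadable from compound 1 to compound 2, has no readable size to carry over. With compound 2 sitting at the limit shown in the limit of > 20000 nM in this assay, at which 2 of the 2 values shown sit, the step that the limit leaves unreadable from compound 2 to compound 3 is expected to leave compound 3 at that same limit, with no number readable. Compound 3 is estimated at 25000 nM in this assay, within 8000 nM to 60000 nM, most likely reported only as a limit.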

Compound 3, half-maximal inhibitory concentration: 2410 nM
The estimate for compound 3 lay 10-fold (1.02 log units) above the measured number, outside the stated range (below it).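

In this assay, the change from 3,4-dimethoxybenzyl to 3-fluoro-4-methoxybenzyl gives an at least 8.2-fold lower number from compound 2 to compound 3 (0.91 log units; beyond the scatter), so this aromatic carbon, ortho to a methoxy group, is the one place in the series where a change has produced a readable number. The 3-fluoro-4-methoxyphenyl group in place of 4-methylphenyl likewise gives an at least 8.2-fold lower number from compound 1 to compound 3 (0.91 log units; beyond the scatter), and both steps are minimum sizes only. Compound 1 and compound 2 remain at a limit of the assay, not at a number: the limit of > 20000 nM in this assay, at which 2 of the 3 values shown sit.

The compounds shown do not separate the entry of fluoro from the loss of methoxy, and a plain hydrogen, a chloro or a hydroxyl on the same carbon would bear on that question. From the compounds shown here alone, the full size of each step also stays open, with one end of each at a limit.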